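Swapping a furan substituent in an adenosine receptor series

The source may hold more compounds than are shown below. What is called first, only, known or untested is meant among the compounds shown, and "the series" means these compounds.

Two compounds in this set share a core bearing an amino group, a furan ring and a pendant benzene ring; they have been tested in a functional assay on CHO-K1 cells for antagonist activity at adenosine receptor A1 (Homo sapiens), read by a beta-galactosidase reporter and cAMP accumulation, with stated times of 15 min and 6 h; a lower number here means a stronger inhibitor, a higher number a weaker inhibitor. Compound 1, `Cc1ccc(-c2nc(N)c3cc(CCc4ccccc4)sc3n2)o1`, gives 2780 nM in this assay. Compound 2, `CC(C)c1ccc(-c2nc(N)c3cc(Cc4ccccc4)sc3n2)o1`, gives 283 nM in this assay, the lower of the two numbers, and the two values are far enough apart to lie beyond the usual scatter. Compounds 1 and 2 differ in more than one place, so the gap between them cannot be traced to a single change.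

Compound 3, `Nc1nc(-c2ccc(C(F)F)o2)nc2sc(Cc3ccccc3)cc12`, has not yet been measured. It differs from compound 2 in one place: difluoromethyl in place of isopropyl on an aromatic carbon. Among the measured compounds shown here, no measured pair in this set shows the effect of this exact change, so the direction of the step is uncertain. A modest weakening seems a reasonable expectation, though a step within the scatter would not surprise. Compound 3 is therefore estimated at 550 nM in this assay, within a range from 150 nM to 2000 nM, an expected step of a 1.9-fold higher number from compound 2 to compound 3 (0.29 log units; within the scatter).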

Compound 3, inhibition constant: 3000 nM
Estimate against measurement, compound 3: 5.5-fold (0.74 log units) below; the measured number lies above the stated range.
By their numbers in this assay, from the lowest: compound 2; then compounds 1 and 3 (each within the scatter of the next).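

Among the compounds shown here, compounds 2 and 3 are the first pair here that differ in only one place, so this gap can be read as the result of a single change: in this assay, replacing 5-isopropylfuran-2-yl with 5-(difluoromethyl)furan-2-yl gives an 11-fold higher number from compound 2 to compound 3 (1.03 log units; beyond the scatter), making compound 3 the weaker inhibitor. The two groups have the same number of heavy atoms, neither has a hydrogen-bond donor or acceptor, and neither carries a net charge, yet the result at this aromatic carbon next to the ring oxygen is far from neutral, so these counts alone do not predict what the swap does here. Nothing in the data shown explains why the step is so large.

From the compounds shown here alone, it remains open whether a plain methyl, an ethyl or a trifluoromethyl group on this same carbon would stay close to compound 2 or fall closer to compound 3 if the rest of the structure were unchanged. Going by these compounds, it is also open whether the same swap would have a similar effect on the longer link to the benzene ring seen in compound 1.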